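From a Sulfanyl Link to an Amino Link

The compounds below may be only part of what the source reports. "The series", "measured", "known", "first", "only" and "open" are said of these compounds alone.

In a functional assay on HCT-116 cells (Homo sapiens) for cytotoxicity, read by MTT assay (on this read-out lower numbers stand for stronger inhibition and higher numbers for weaker inhibition), compound 1 (`Nc1ccccc1NC(=O)c1ccc(CSc2ccccn2)cc1`) gives 1000 nM. Among the compounds with values here, compound 2 (`Cc1ccc(C#N)c(OCc2ccc(C(=O)Nc3ccccc3N)cc2)n1`) gives 500 nM there, and these two values lie within the usual scatter of each other, so compound 1 stands level with the only other measured compound. Compound 3 (`Nc1ccccc1NC(=O)c1ccc(CNc2cccc(F)n2)cc1`) carries (6-fluoropyridin-2-yl)amino in place of (pyridin-2-yl)sulfanyl on a saturated chain carbon bound to an aromatic carbon. Within the data shown here, no measured pair shows this change, so no step beyond the scatter is expected in this assay, in either direction. The expected step is a 1.4-fold lower number from compound 1 to compound 3 (0.15 log units; within the scatter). For compound 3 the estimated value is 700 nM, with an expected range of 250 nM to 2000 nM.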

Compound 3, half-maximal inhibitory concentration: 1000 nM
Estimate against measurement, compound 3: 1.4-fold (0.15 log units) below, and the stated range covers the measured number.
By their numbers in this assay, from the lowest: compounds 2, 1 and 3 (each within the scatter of the next).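

In this assay, placing (6-fluoropyridin-2-yl)amino in place of (pyridin-2-yl)sulfanyl on a saturated chain carbon bound to an aromatic carbon gives no change at the digits printed from compound 1 to compound 3 (within the scatter). Within the data shown here, this is the first single-place comparison at this position, and it shows that the change of link, the added fluorine and the added hydrogen-bond donor together leave the read-out within the scatter. Nothing available explains this result. The compounds shown leave open what the link and the fluorine each do alone, as both change together. A (pyridin-2-yl)amino group would separate the two.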